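The compounds below may be only part of what the source reports. "The series", "measured", "known", "first", "only" and "open" are said of these compounds alone.

In a functional assay on IMR-32 cells (Homo sapiens) for antiproliferative activity, read by MTT assay (on this read-out lower numbers stand for stronger inhibition and higher numbers for weaker inhibition), compound 1 `COc1ccc(-n2cc(COc3ccc(/C=C/C(=O)c4ccc5c(c4O)CCC(C)(C)O5)cc3)nn2)c([N+](=O)[O-])c1` gives 132000 nM, a weak result. The entry for compound 2 `Cc1ccc(-n2cc(COc3ccc(/C=C/C(=O)c4ccc5c(c4O)CCC(C)(C)O5)cc3)nn2)cc1Br` reads "not active" (no number reported), so it offers no single number as a starting point. Compound 3 `CCCCCCCCn1cc(COc2ccc(/C=C/C(=O)c3ccc4c(c3O)CCC(C)(C)O4)cc2)nn1` differs from it by octyl in place of 3-bromo-4-methylphenyl on an aromatic nitrogen, with octyl in place of 3-bromo-4-methylphenyl on an aromatic nitrogen. Among the measured compounds shown here, no measured pair shows what such a swap does, so only a modest gain is expected in this assay, from no number to a weak one, near compound 1 at 132000 nM. The estimate for compound 3 is 60000 nM, with an expected range of 15000 nM to 200000 nM.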

Compound 3, half-maximal inhibitory concentration: "not active" (no number reported)
No number was reported for compound 3; the estimate stays without a comparison.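

Among the compounds shown here, compound 2 and compound 3 both read "not active", so no step in potency can be read between them. From the compounds shown here alone, whether octyl or 3-bromo-4-methylphenyl on the aromatic nitrogen serves activity better stays open. No supporting evidence bears on this result.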